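The compounds below may be only part of what the source reports. "The series", "measured", "known", "first", "only" and "open" are said of these compounds alone.

Measured so far:
- compound 1 `C=C(Br)C(=O)Nc1ccc(/C=C/C(=O)c2ccc(Cl)c(Cl)c2)cc1` gives 1800 nM in a functional assay on MOLT-4 cells (Homo sapiens) for antiproliferative activity, with a stated time of 48 h; a lower number here means a stronger inhibitor, a higher number a weaker inhibitor
- compound 2 `C=C(Br)C(=O)Nc1ccc(/C=C/C(=O)c2ccc(C)cc2)cc1` gives 1700 nM in this assay

Going by the values given here, only these two numbers exist, and compound 2 stands beside compound 1 alone: the single measured step, a 1.1-fold lower number from compound 1 to compound 2 (0.02 log units; within the scatter), lies within the scatter, so the two compounds cannot be told apart in this assay on the evidence at hand.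

Compound 3 `Cc1ccc(C(=O)/C=C/c2ccc(N)cc2)cc1` is the next compound to be tested. It differs from compound 2 by hydrogen in place of (1-bromoethenyl)carbonyl on a nitrogen on an aromatic ring. Among the compounds with values here, the one measured step compares the 4-methylphenyl and 3,4-dichlorophenyl groups on the carbonyl carbon and leaves the nitrogen on the aromatic ring untouched, so no measured step bears directly on the change from compound 2 to compound 3. Without any such comparison, the expectation for compound 3 rests on the fact that the (1-bromoethenyl)carbonyl group is removed entirely rather than exchanged. Compound 3 is therefore estimated to give a weaker result, 15000 nM, in the range 3000 nM to 60000 nM, which would correspond to an expected step of an 8.8-fold higher number from compound 2 to compound 3 (0.95 log units; beyond the scatter).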

Compound 3, half-maximal inhibitory concentration: 12000 nM
Estimate against measurement, compound 3: 1.3-fold (0.10 log units) above, and the stated range covers the measured number.
By their numbers in this assay, from the lowest: compounds 2 and 1 (each within the scatter of the next); then compound 3.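

Up to now, the only measured change lay on the carbonyl carbon and stayed within the scatter, so nothing showed whether any part of these compounds mattered in this assay. Going by these compounds alone, the change on the nitrogen on the aromatic ring is the first to go beyond the scatter: replacing (1-bromoethenyl)carbonyl with hydrogen gives a 7.1-fold higher number from compound 2 to compound 3 (0.85 log units; beyond the scatter), a modest loss that leaves compound 3 with a measurable 12000 nM, so the amino compound retains some antiproliferative activity without this group. Nothing at hand accounts for the size of this step.

The compounds shown leave open which part of the (1-bromoethenyl)carbonyl group carries the difference, since an acetyl group, a plain acryloyl group or a 2-chloroacryloyl group on the same nitrogen would separate the carbonyl, the double bond and the bromine. They also leave open whether removing the group would cost as much with 3,4-dichlorophenyl in place of 4-methylphenyl on the carbonyl carbon.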